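The source may hold more compounds than are shown below. What is called first, only, known or untested is meant among the compounds shown, and "the series" means these compounds.

Series notes. Two compounds have been run in an ADME assay on HEK293 cells (Homo sapiens) for cytotoxicity, with a stated time of 72 h; a lower number here means that less compound is needed, a higher number that more compound is needed for the effect. Compound 1 `O=C(Nc1nc(-c2cccc(F)c2)cs1)c1cc([N+](=O)[O-])ccc1Cl` gives 8700 nM in this assay. For compound 2 `O=C(Nc1cccc(-c2nc3ccccc3s2)c1)c1cc([N+](=O)[O-])c(O)cc1Cl`, this assay returns only a limit, > 25000 nM, so its number is not known. Compound 2 therefore stands at the limit of > 25000 nM in this assay, at which 1 of the 2 values shown sits, rather than at a value. Within the data shown here, of the pair, compound 1 reached a number while compound 2 did not; no step between them is computed, as they differ in more than one place. Compound 3 `O=C(O)COc1cc(Cl)c(C(=O)Nc2cccc(-c3nc4ccccc4s3)c2)cc1[N+](=O)[O-]` is compound 2 with one change, (carboxymethyl in place of hydrogen on an oxygen on an aromatic ring). Among the measured compounds shown here, no measured pair in the set shares this change, so no measured step sets the expectation. The step expected in this assay, a step that the limit leaves unreadable from compound 2 to compound 3, is taken as none beyond the scatter, with the result most likely again reported as a limit. For compound 3 the estimate in this assay is 30000 nM, with a range from 12000 nM to 80000 nM.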

Compound 3, half-maximal effective concentration: > 25000 nM
Compound 3 was reported as a limit; the forecaster's own chance of this, stated with the estimate: 70%; the middle value does not contradict the limit.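

No step can be read between compound 2 and compound 3, as both are reported only as limits in this assay: the limit of > 25000 nM in this assay, at which 2 of the 3 values shown sit. The compounds shown leave open whether carboxymethyl in place of hydrogen on an oxygen on an aromatic ring shifts this read-out at all.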